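The source may hold more compounds than are shown below. What is called first, only, known or untested is meant among the compounds shown, and "the series" means these compounds.

Compound 1 `O=C(CCCCCCc1nc(-c2cccc([N+](=O)[O-])c2)no1)NO` gives 2380 nM in an assay on isolated protein for inhibition of histone deacetylase 8 (Homo sapiens), read by fluorescence, with a stated time of 10 min; on this read-out higher numbers stand for weaker inhibition and lower numbers for stronger inhibition.
Compound 2 `Nc1ccccc1NC(=O)CCCCCCc1nc(-c2ccc(C(F)(F)F)cc2)no1` gives > 10000 nM in this assay, which is a limit of the assay and not a number.

Among the compounds with values here, compound 1 is therefore the only compound of the pair with a numerical reading in this assay; the other value sits at the limit of > 10000 nM in this assay, at which 1 of the 2 values shown sits, so no step between two measured compounds can be drawn, and compound 1 stands alone as the reference point.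

The compound that remains to be measured is compound 3 `O=C(CCCCCCc1nc(-c2cccc([N+](=O)[O-])c2)no1)C(F)(F)F`. It keeps the whole of compound 1 apart from one change: trifluoromethyl in place of hydroxyamino on a carbonyl carbon. The hydroxyamino group of the hydroxycarbamoyl end leaves, and a trifluoromethyl group takes its place on the same carbonyl carbon, so the chain and the core are unchanged.

Within the data shown here, with no measured step of this kind to lean on, the expectation rests on compound 1 alone. The step from compound 1 to compound 3 is expected to run toward weaker inhibition, by a 3.4-fold higher number from compound 1 to compound 3 (0.53 log units; beyond the scatter), which is beyond the usual scatter. Compound 3 is accordingly estimated at 8000 nM in this assay, with a likely range from 1500 nM to 40000 nM.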

Compound 3, half-maximal inhibitory concentration: 830 nM
Estimate against measurement, compound 3: 9.6-fold (0.98 log units) above; the whole stated range lies above it.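

In this assay the first step read at this carbonyl carbon, trifluoromethyl in place of hydroxyamino, is a 2.9-fold lower number from compound 1 to compound 3 (0.46 log units; beyond the scatter) and shows that, with the chain and the core of compound 1 held unchanged, the hydroxycarbamoyl end is not required for inhibition on this read-out. The (trifluoromethyl)carbonyl end gives up the hydrogen-bond donors and the acceptor counted for hydroxyamino, and inhibition still grows stronger, so in this one pair those donors and that acceptor are not needed for the reading of compound 3. Nothing measured here explains the step, and a single pair sets no pattern.

As far as these compounds go, it remains open whether other groups on the same carbonyl carbon, such as a methyl group, an amine or a hydroxyl group giving a carboxylic acid, would read nearer to compound 1 or to compound 3. Also open, from the compounds shown here alone, is whether the step from hydroxyamino to trifluoromethyl keeps its direction and size with a shorter or longer chain, or with a trifluoromethyl group or a nitrile on the aromatic ring in place of the nitro group.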